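Sulfonamide oxadiazole series: arylamino replacing benzyl on the core

The compounds below may be only part of what the source reports. "The series", "measured", "known", "first", "only" and "open" are said of these compounds alone.

Compound 2 `Cc1ccc(S(=O)(=O)N(Cc2nnc(Cc3cccc(F)c3)o2)c2cccc(Cl)c2C)cc1` is measured in a functional assay on CHO cells for antagonist activity at prostaglandin E2 receptor EP1 subtype (Homo sapiens), read by FLIPR and calcium flux (a lower number here means a stronger inhibitor, a higher number a weaker inhibitor), at 501 nM. On the numbers shown it is the second highest of three. Its nearest neighbour is compound 1 `Cc1ccc(S(=O)(=O)N(Cc2nnc(Cc3ccccc3F)o2)c2cccc(Cl)c2C)cc1`, which gives 631 nM in this assay; the step of a 1.3-fold lower number from compound 1 to compound 2 (0.10 log units; within the scatter) is within the scatter, so the two are indistinguishable. The furthest is compound 3 `CCc1ccccc1N(Cc1nnc(Oc2ccc(OC)cc2)o1)S(=O)(=O)c1ccc(C)cc1`, which gives 100 nM in this assay, a value beyond the scatter from compound 2, but compound 3 differs from compound 2 in more than one place, so no single step can be read from that gap.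

Compound 4 `COc1ccc(Nc2nnc(CN(c3cccc(Cl)c3C)S(=O)(=O)c3ccc(C)cc3)o2)cc1` differs from compound 2 as follows: (4-methoxyphenyl)amino in place of 3-fluorobenzyl on an aromatic carbon. Among the measured compounds shown here, the only measured step, from compound 1 to compound 2, alters the ring substitution inside the benzyl group and says nothing about exchanging the benzyl for an arylamino group, so no directly relevant step exists. The substituent entering in compound 4 has more in common with what compound 3 carries on the same core position than with the benzyl of compound 2.

The estimate for compound 4 is therefore a moderate move toward lower numbers, a 2.0-fold lower number from compound 2 to compound 4 (0.30 log units; within the scatter), with wide uncertainty. Compound 4 is expected at 250 nM in this assay, within a range from 80 nM to 800 nM.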

Compound 4, inhibition constant: 79.4 nM
For compound 4 the middle estimate is 3.1-fold (0.50 log units) above the measured one; the measured number lies below the stated range.
By their numbers in this assay, from the lowest: compounds 4 and 3 (each within the scatter of the next); then compounds 2 and 1 (each within the scatter of the next).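

Among the compounds shown here, on the aromatic carbon of the five-membered ring of the shared core, (4-methoxyphenyl)amino in place of 3-fluorobenzyl gives, in this assay, a 6.3-fold lower number from compound 2 to compound 4 (0.80 log units; beyond the scatter), the first single-place change in this set to lie beyond the scatter, whereas moving the fluorine within the benzyl group did not separate compound 1 from compound 2. The same exchange made against 2-fluorobenzyl gives a 7.9-fold lower number from compound 1 to compound 4 (0.90 log units; beyond the scatter), so the result at this position does not rest on one fluorobenzyl isomer as the starting point. No available measurement bears on the reason for this change in this assay.

The exchange alters several things at once: the benzyl carbon gives way to an amino link, which brings a hydrogen-bond donor that the fluorobenzyl groups lack, and the ring fluorine gives way to a methoxy group, so the compounds shown cannot assign the step to either part. A (3-fluorophenyl)amino group would separate the link from the ring substituent, while a 4-methoxybenzyl group would test the methoxy group without the amino link, and an N-methyl-N-arylamino group would show whether the amino hydrogen matters.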